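The compounds below may be only part of what the source reports. "The series", "measured", "known", "first", "only" and "open" are said of these compounds alone.

Going by the values given here, in a functional assay on A549 cells (Homo sapiens) for antiproliferative activity, read by MTT assay, with a stated time of 72 h (a higher number here means a weaker inhibitor, a lower number a stronger inhibitor), compound 3 `CCCCCCCCCCCCCCNC[C@@H]1OC[C@H](N)[C@H]1O` gives 20000 nM, the only actual number in this small set. Compound 1 `CCCCCCCCNC[C@@H]1OC[C@H](N)[C@@H]1O` reports only a limit, > 128000 nM. Compound 2 `CCCCCCCCCNC[C@@H]1OC[C@H](N)[C@H]1O` also reports only a limit, > 128000 nM. The series is thus bounded by the limit of > 128000 nM in this assay, at which 2 of the 3 values shown sit. The next compound, compound 4 `CCCCCCCCNC[C@@H]1OC[C@H](N)[C@H]1O`, differs from compound 3 by hydrogen in place of hexyl on a saturated chain carbon, eight bonds along the chain from an amine nitrogen, with hydrogen in place of hexyl on a saturated chain carbon. Among the compounds with values here, the one measured step that bears on this is an at least 6.4-fold lower number from compound 2 to compound 3 (0.80 log units; beyond the scatter), which added pentyl. Removing hexyl runs the opposite way, so a loss of at least similar size is expected. The expected change is a 6.4-fold higher number from compound 3 to compound 4 (0.81 log units; beyond the scatter), toward a higher number in this assay. For compound 4 the estimated value is 128000 nM, within a range of 64000 nM to 256000 nM, and it may well be reported only as a limit.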

Compound 4, half-maximal inhibitory concentration: 71800 nM
Compound 4: middle estimate off by 1.8-fold (0.25 log units), on the high side; measured number inside the range.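

In this assay hydrogen in place of hexyl on a saturated chain carbon, eight bonds along the chain from an amine nitrogen, gives a 3.6-fold higher number from compound 3 to compound 4 (0.56 log units; beyond the scatter) and so this change now rests on two actual numbers, where the earlier step rested on a limit. Hydrogen in place of methyl on a saturated chain carbon, eight bonds along the chain from an amine nitrogen, gives an at least 1.7-fold lower number from compound 2 to compound 4 (0.25 log units; that floor lies within the scatter). The change in configuration at a saturated ring carbon gives an at least 1.7-fold lower number from compound 1 to compound 4 (0.25 log units; that floor lies within the scatter). Both of these steps start from a limit and their floors lie within the scatter: the limit of > 128000 nM in this assay, at which 2 of the 4 values shown sit.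

From the compounds shown here alone, whether the configuration of the ring carbon matters therefore stays open: the fact that compounds 1 and 4 differ only in the configuration as drawn. Also open, going by these compounds, is whether a chain longer than that of compound 3, or one ending in a carboxylic acid, would lower the number further.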